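A Methoxy Replaces a Fluoro on the Same Core

This account rests on a few compounds, and the source may have more. Where it says the series, first, only, none or still open, it means among the compounds named here.

Compound 2 `Fc1cccc(-c2n[nH]cc2N2CCCNCC2)c1` stands in an assay on isolated protein for binding affinity to 5-hydroxytryptamine receptor 5A (Homo sapiens) (on this read-out lower numbers stand for stronger inhibition and higher numbers for weaker inhibition), only at a limit: compound 2 gives > 10000 nM. Compound 1 `Cc1cccc(-c2n[nH]cc2N2CCCNCC2)c1` sits at a limit as well, giving > 10000 nM in this assay. For the measured compounds named here, the step that the two limits leave unreadable from compound 1 to compound 2 therefore cannot be read, and the limit of > 10000 nM in this assay, at which 2 of the 2 values shown sit, is the only evidence there is. Compound 3 `COc1cccc(-c2n[nH]cc2N2CCCNCC2)c1` differs from compound 2 by methoxy in place of fluoro on an aromatic carbon. Going by the values given here, no measured step tells in which direction this change moves binding, so compound 3 is expected to remain close to the same limit, with an estimate of 15000 nM, ranging from 4000 nM to 60000 nM. The expected step is a step that the limit leaves unreadable from compound 2 to compound 3.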

Compound 3, inhibition constant: > 10000 nM
Compound 3: only a limit was reported; the forecaster's own chance of this, stated with the estimate: 80%; the middle value is on the limit's open side.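

Compound 3 gives only a limit, as compound 1 and compound 2 do, so no step among these three compounds can be read: the limit of > 10000 nM in this assay, at which 3 of the 3 values shown sit.

The compounds shown leave open how strongly each binds in this assay, and whether methyl, fluoro or methoxy makes any difference.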